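Series notes: tert-butyl to phenyl exchange on the shared core

The compounds below may be only part of what the source reports. "The series", "measured", "known", "first", "only" and "open" are said of these compounds alone.

Measured so far, in an assay on isolated protein for inhibition of serine/threonine-protein kinase 10 (Homo sapiens), read by thermal shift assay, tested at 10 uM; a lower number here means that the compound stabilises the target less, a higher number that the compound stabilises the target more against heat:
compound 1, `Cn1nc(C(C)(C)C)cc1NC(=O)Nc1cc(C(F)(F)F)cc(C(F)(F)F)c1`, gives 1.1 degrees C;
compound 2, `Cn1nc(-c2ccccc2)cc1NC(=O)Nc1cc(C(F)(F)F)cc(C(F)(F)F)c1`, gives 2.6 degrees C;
compound 3, `Cn1nc(C(C)(C)C)cc1NC(=O)Nc1cc(F)cc(F)c1`, gives 1.1 degrees C.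

From compound 1 to compound 2 the change is phenyl in place of tert-butyl on an aromatic carbon, and it gave a number 1.5 degrees C higher from compound 1 to compound 2 (beyond the scatter). Compound 1 and compound 3 differ in the other part of the molecule; that difference between the two cores is not broken down here. Compound 3 and compound 1 stand level in this assay, within the scatter.

Compound 4, `Cn1nc(-c2ccccc2)cc1NC(=O)Nc1cc(F)cc(F)c1`, is not yet measured. It differs from compound 3 by phenyl in place of tert-butyl on an aromatic carbon, the same change as from compound 1 to compound 2. If the step carries over, a shift of a number 1.4 degrees C higher from compound 3 to compound 4 (beyond the scatter) is expected for compound 4, resting on compound 1 going to compound 2 with a number 1.5 degrees C higher from compound 1 to compound 2 (beyond the scatter). The estimate for compound 4 in this assay is 2.5 degrees C, expected between 1.2 degrees C and 3.8 degrees C.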

Compound 4, shift of the target's melting temperature: -0.7 degrees C
Beside the measured number, compound 4's estimate is 3.2 degrees C above it, outside the stated range (below it).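

In this assay, phenyl in place of tert-butyl on an aromatic carbon does not carry over between the two cores: the step reverses in sign, with a number 1.8 degrees C lower from compound 3 to compound 4 (beyond the scatter) on the second core. The two steps set side by side differ: the same change on two cores in this assay, a number 1.5 degrees C higher (beyond the scatter) from compound 1 to compound 2 and a number 1.8 degrees C lower (beyond the scatter) from compound 3 to compound 4, 3.3 degrees C apart, beyond the scatter of two such steps. So the step seen on one core is no guide to the other here, though with a single pair on each core this does not show which feature of the cores sets the difference, or whether the reversal is general.

Open, as far as these compounds go, is how other groups at this place, such as an amine or a longer chain, behave on each core. Also open, from the compounds shown here alone, is whether a core bearing chlorine or a nitrile would follow the core of compound 1 or that of compound 3.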